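A smaller group on the amide nitrogen of compound 1

This account rests on a few compounds, and the source may have more. Where it says the series, first, only, none or still open, it means among the compounds named here.

Compound 1 (`Cc1c(C)c2c(c(C)c1OC(=O)CCC(=O)O)CCC(C)(C(=O)NCC1CC(C)(C)N([O])C1(C)C)O2`) gives > 300000 nM (a limit)
Compound 2 (`Cc1c(C)c2c(c(C)c1O)CCC(C)(C(=O)NCC1CC(C)(C)N([O])C1(C)C)O2`) gives 192000 nM
Compound 3 (`Cc1c(C)c2c(c(C)c1OC(=O)CCC(=O)NCC1CC(C)(C)N([O])C1(C)C)CCC(C)(C(=O)NCC1CC(C)(C)N([O])C1(C)C)O2`) gives 50000 nM

In a toxicity assay on cells (Cricetulus griseus) for cytotoxicity, read by MTT assay, with a stated time of 72 h (a lower number here means a stronger inhibitor, a higher number a weaker inhibitor), compound 1 stands at the limit of > 300000 nM in this assay, at which 1 of the 3 values shown sits, and so has a limit, not a number. Compound 4 (`Cc1c(C)c2c(c(C)c1OC(=O)CCC(=O)O)CCC(C)(C(=O)NC1CC(C)(C)N([O])C1(C)C)O2`) keeps the core of compound 1 and differs only on an amide-type nitrogen (a group of 10 heavy atoms (8 carbon, 1 nitrogen, 1 oxygen; one five-membered non-aromatic ring with 1 hetero atom) in place of a group of 11 heavy atoms (9 carbon, 1 nitrogen, 1 oxygen; one five-membered non-aromatic ring with 1 hetero atom), on an amide-type nitrogen). Two measured steps start from compound 1. One (an at least 1.5-fold lower number from compound 1 to compound 2 (0.19 log units; that floor lies within the scatter)) changes an oxygen on an aromatic ring, and the other (an at least 6.0-fold lower number from compound 1 to compound 3 (0.77 log units; beyond the scatter)) changes a carbonyl carbon. Neither touches this nitrogen, so neither sets a size for the new step, and no change beyond the scatter is expected in this assay (a step that the limit leaves unreadable from compound 1 to compound 4). The expected value for compound 4 is 350000 nM (estimated range 150000 nM to 800000 nM).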

Compound 4, half-maximal inhibitory concentration: > 300000 nM
Compound 4 was reported as a limit; the forecaster's own chance of this, stated with the estimate: 65%; the middle value is on the limit's open side.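

Compound 1 and compound 4 both give a limit rather than a number, so no step between them can be read: the limit of > 300000 nM in this assay, at which 2 of the 4 values shown sit.

The compounds shown leave open whether the shorter group on the amide-type nitrogen changes the result in this assay at all.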